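Phenyl to cyclohexyl on compound 2

The source may hold more compounds than are shown below. What is called first, only, known or untested is meant among the compounds shown, and "the series" means these compounds.

- Compound 1 `O=C(NCc1cc(Cl)ccc1-n1cnnn1)[C@@H]1[C@@H]2C[C@@H]2CN1C(=O)[C@H](O)Cc1ccccn1` gives 1700 nM
- Compound 2 `O=C(NCc1cc(Cl)ccc1-n1cnnn1)[C@@H]1CC=NN1C(=O)[C@H](O)c1ccccc1` gives 840 nM
- Compound 3 `O=C(NCc1cc(Cl)ccc1-n1cnnn1)[C@@H]1[C@H]2C[C@H]2CN1C(=O)[C@H](O)Cn1cccn1` gives 1800 nM

All three numbers come from a functional assay on a cell-free system (plasma, Homo sapiens), with a stated time of 3 min (on this read-out lower numbers stand for stronger inhibition and higher numbers for weaker inhibition), and they place compound 2 lowest, which makes it the strongest inhibitor of the three. Its gaps to compound 1 and to compound 3 both lie beyond the usual scatter of repeated measurements, though only just.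

Compound 4 `O=C(NCc1cc(Cl)ccc1-n1cnnn1)[C@@H]1CC=NN1C(=O)[C@H](O)C1CCCCC1` has cyclohexyl in place of phenyl on a saturated chain carbon bound to a carbonyl carbon and an oxygen on a saturated carbon. A six-membered aromatic ring of carbon only leaves, and a six-membered non-aromatic ring of carbon only enters, so the rest of compound 2 stays untouched.

Among the compounds with values here, no measured pair tests this swap on its own. Compound 1 and compound 3 differ from compound 2 in more than one place, so they offer only a rough sense of the range of values. With so little to go on, no change beyond the scatter is expected in this assay, in either direction. The estimated step of a 1.1-fold lower number from compound 2 to compound 4 (0.05 log units; within the scatter) is therefore small, and the uncertainty around it is wide. For compound 4 the expected value is 750 nM, with an estimated range from 200 nM to 2800 nM as the likely outcome.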

Compound 4, half-maximal inhibitory concentration: 970 nM
Estimate against measurement, compound 4: 1.3-fold (0.11 log units) below, and the stated range covers the measured number.
By their numbers in this assay, from the lowest: compounds 2, 4, 1 and 3 (each within the scatter of the next, the first and the last beyond it).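

In this assay, within the data shown here, the swap of phenyl for cyclohexyl on a saturated chain carbon bound to a carbonyl carbon and an oxygen on a saturated carbon gives a 1.2-fold higher number from compound 2 to compound 4 (0.06 log units; within the scatter), and this is the first comparison in the set that changes only one place. It shows that, on this core and at this position, a six-membered aromatic ring of carbon only and a six-membered non-aromatic ring of carbon only cannot be told apart by this read-out, so the aromatic ring of compound 2 is not needed to keep the number where it stands. Nothing measured on these compounds explains why the two rings read alike.

From the compounds shown here alone, both rings have six carbons and no hydrogen-bond donors or acceptors, so it remains open whether any ring is needed here, or whether a methyl group, a piperidine ring carrying an amine or a carboxylic acid would keep the number in the same range. Going by these compounds, compound 1 and compound 3 differ from compound 2 in more than one place, so the same swap on their cores remains untested.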